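Amide nitrogen exchange in a trisubstituted alkene amide series

The source may hold more compounds than are shown below. What is called first, only, known or untested is meant among the compounds shown, and "the series" means these compounds.

Measured so far, in a toxicity assay on the whole organism (strain Icem-CET (SPF Caw)) for cytotoxicity, with Mus musculus as the target; on this read-out lower numbers stand for an effect already at smaller amounts and higher numbers for an effect only at larger amounts of compound:
compound 1 `C#CCNC(=O)/C(C)=C(\C)c1cc(OC)c(OC)c(OC)c1` gives 300 mg/kg.
compound 2 `C#CCNC(=O)/C(C)=C(\C)c1ccc(C)cc1` gives 200 mg/kg.
compound 3 `C/C(C(=O)NC1CC1)=C(/C)c1ccc(C)cc1` gives 300 mg/kg.

Compounds 2 and 3 differ in one place, (cyclopropyl in place of propargyl on an amide-type nitrogen), and the step is a 1.5-fold higher number from compound 2 to compound 3 (0.18 log units; within the scatter). Compound 1 and compound 3 sit level at the digits read in this assay; compound 1 and compound 2 differ by an amount within the scatter. The difference between the core of compound 1 and the core of compound 2 is not broken down here.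

Not yet measured is compound 4 `COc1cc(/C(C)=C(\C)C(=O)NC2CC2)cc(OC)c1OC`, which relates to compound 1 as compound 3 relates to compound 2: cyclopropyl in place of propargyl on an amide-type nitrogen. Both changes sit on the same kind of nitrogen with the same neighbour, so the change is the same. Because a 1.5-fold higher number from compound 2 to compound 3 (0.18 log units; within the scatter) stayed within the scatter, a step of about the same size is expected from compound 1, namely a 1.2-fold higher number from compound 1 to compound 4 (0.07 log units; within the scatter). Compound 4 is thus estimated at 350 mg/kg, with a range from 200 mg/kg to 600 mg/kg.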

Compound 4, dose for half-maximal effect: > 800 mg/kg
Compound 4: no number, only a limit; the forecaster's own chance of this, stated with the estimate: 5%; at least 2.2-fold (0.35 log units) between middle value and limit.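

In this assay compound 4 gives > 800 mg/kg, which is a limit of the assay and not a number. Cyclopropyl in place of propargyl on an amide-type nitrogen gives an at least 2.6-fold higher number from compound 1 to compound 4 (0.42 log units; beyond the scatter) on the core of compound 1, and a 1.5-fold higher number from compound 2 to compound 3 (0.18 log units; within the scatter) on the core of compound 2. The step thus lies beyond the scatter on one core and within it on the other, but this does not show that the change differs in size between the cores: the same change on two cores in this assay, a 1.5-fold higher number (0.18 log units; within the scatter) from compound 2 to compound 3 and an at least 2.6-fold higher number (0.42 log units; beyond the scatter) from compound 1 to compound 4; the limit leaves it open whether they differ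

Where the actual value of compound 4 lies remains open. Also open, as far as these compounds go, is how a longer chain such as butyl on the same amide-type nitrogen would behave on either core.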